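The source may hold more compounds than are shown below. What is called first, only, known or untested is meant among the compounds shown, and "the series" means these compounds.

Three compounds on the shared core have numbers in an ADME assay on HepG2 cells (Homo sapiens) for cytotoxicity, read by MTT assay, with a stated time of 7 days; a lower number here means a stronger inhibitor, a higher number a weaker inhibitor. Compound 1 `O=C(c1cccnc1)N1N=C(c2ccc(O)cc2)CC1c1ccc(F)cc1` gives 52400 nM, compound 2 `O=C(c1cccnc1)N1N=C(c2ccc(O)cc2)CC1c1ccc(Br)cc1` gives 58700 nM, and compound 3 `Cc1cc(C)c(C2CC(c3ccc(O)cc3)=NN2C(=O)c2cccnc2)c(C)c1` gives 54500 nM. Compound 1 has the lowest of the three numbers, but a 1.1-fold higher number from compound 1 to compound 2 (0.05 log units; within the scatter) and a 1.0-fold higher number from compound 1 to compound 3 (0.02 log units; within the scatter) are both small, so no order among the three can be read from these values.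

Compound 4 `CC(C)c1ccccc1C1CC(c2ccc(O)cc2)=NN1C(=O)c1cccnc1` has not yet been measured in this assay. Relative to compound 1 the change is 2-isopropylphenyl in place of 4-fluorophenyl on a saturated ring carbon. Among the measured compounds shown here, two measured steps touch the same saturated ring carbon: a 1.0-fold higher number from compound 1 to compound 3 (0.02 log units; within the scatter) and a 1.1-fold lower number from compound 2 to compound 3 (0.03 log units; within the scatter). Both replaced a para-substituted phenyl by 2,4,6-trimethylphenyl and neither moved the number beyond the scatter. The swap of bromo for fluoro, a 1.1-fold higher number from compound 1 to compound 2 (0.05 log units; within the scatter), was likewise flat. Nothing in this set shows the group on that carbon shifting cytotoxicity in this assay.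

For compound 4 the expected step is therefore a 1.0-fold higher number from compound 1 to compound 4 (0.01 log units; within the scatter), no more than the scatter would give. The estimate for compound 4 in this assay is 54000 nM, with a range from 30000 nM to 97000 nM.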

Compound 4, half-maximal inhibitory concentration: 49700 nM
Beside the measured number, compound 4's estimate is 1.1-fold (0.04 log units) above it; the range from low to high includes it.
By their numbers in this assay, from the lowest: compounds 4, 1, 3 and 2 (each within the scatter of the next).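

In this assay, a branched alkyl substituent on the phenyl at the saturated ring carbon is new to the series, and 2-isopropylphenyl in place of 4-fluorophenyl gives a 1.1-fold lower number from compound 1 to compound 4 (0.02 log units; within the scatter). Among the compounds shown here, the comparisons with the other two aryl groups read the same way, with a 1.1-fold lower number from compound 3 to compound 4 (0.04 log units; within the scatter) and a 1.2-fold lower number from compound 2 to compound 4 (0.07 log units; within the scatter), so the halogen-bearing, methyl-bearing and isopropyl-bearing phenyls at this carbon give no step beyond the scatter, and no compound of the four goes against this. Nothing available bears on why the number stays flat across these groups.

All four compounds keep an aryl group at this carbon, along with the 4-hydroxyphenyl and (pyridin-3-yl)carbonyl groups, so the compounds shown say nothing about how much either of those two groups contributes to the number. Also open, going by these compounds, is whether a phenyl carrying an amine or a carboxylic acid, or a saturated group such as cyclohexyl at this carbon, would move the number beyond the scatter.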